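A benzothiazolyl swap on compound 1

The source may report more compounds than this note shows. Statements on the series, on what has been measured and on what is new or still open speak of the compounds shown alone.

Measured in an ADME assay on HepG2 cells (Homo sapiens) for cytotoxicity, with a stated time of 72 h; a lower number here means that less compound is needed, a higher number that more compound is needed for the effect:
compound 1 `O=C(Nc1ccc(F)c(-c2nc3ccccc3o2)c1)c1cc([N+](=O)[O-])ccc1Cl` gives > 25000 nM (a limit)
compound 2 `Cc1ccc(-c2nc3ccccc3s2)cc1NC(=O)c1cc([N+](=O)[O-])c(N(C)C)cc1Cl` gives > 25000 nM (a limit)
compound 3 `Cc1cc(NC(=O)c2cc([N+](=O)[O-])ccc2Cl)cc(-c2nc3ccccc3o2)c1O` gives > 25000 nM (a limit)

Compound 1 has no numerical value in this assay and stands only at the limit > 25000 nM in that measurement. The other two compounds stand the same way, giving the limit of > 25000 nM in this assay, at which 3 of the 3 values shown sit, and leaving no numerical value in the set.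

Within the data shown here, compound 4 `O=C(Nc1ccc(F)c(-c2nc3ccccc3s2)c1)c1cc([N+](=O)[O-])ccc1Cl` keeps the core of compound 1 but has 1,3-benzothiazol-2-yl in place of 1,3-benzoxazol-2-yl on an aromatic carbon, ortho to a fluoro group, as counted in 1,3-benzothiazol-2-yl in place of 1,3-benzoxazol-2-yl on an aromatic carbon (the only change).

Among the measured compounds shown here, no measured step shows what such a change does. Compound 2, which also carries 1,3-benzothiazol-2-yl, reaches only the limit > 25000 nM and so gives no sign of a lower value. In this assay the estimate is that a step that the limit leaves unreadable from compound 1 to compound 4 is expected to stay within the scatter, in neither direction.

Compound 4 is expected at 30000 nM with an estimated range from 12000 nM to 60000 nM and may well return only a limit.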

Compound 4, half-maximal effective concentration: > 25000 nM
Compound 4: only a limit was reported; the forecaster's own chance of this, stated with the estimate: 85%; the middle value does not contradict the limit.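

Among these compounds, compound 1 and compound 4 both stop at a limit in this assay, so no step between them can be read: the limit of > 25000 nM in this assay, at which 4 of the 4 values shown sit.

The compounds shown leave open whether 1,3-benzothiazol-2-yl in place of 1,3-benzoxazol-2-yl changes the value at all, as none of them gives a number.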